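Methyl-to-ethyl step on the ring amine in two series

The source may hold more compounds than are shown below. What is called first, only, known or untested is meant among the compounds shown, and "the series" means these compounds.

Compound 1 `CN1C/C(=C\c2ccccc2F)C(=O)/C(=C/c2ccccc2F)C1` carries a methyl on the ring amine nitrogen. In a functional assay on HCT-116 cells (Homo sapiens) for cytotoxicity, read by MTT assay, with a stated time of 72 h (a higher number here means a weaker inhibitor, a lower number a stronger inhibitor), compound 1 gives 1300 nM. Compound 3 `CCN1C/C(=C\c2ccccc2F)C(=O)/C(=C/c2ccccc2F)C1` differs from compound 1 by methyl in place of hydrogen on a saturated chain carbon bound to an amine nitrogen in a ring; in this assay compound 3 gives 1800 nM, and the step of a 1.4-fold higher number from compound 1 to compound 3 (0.14 log units; within the scatter) is within the scatter, so the two values are not told apart.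

Compound 2 `CN1C/C(=C\c2c(F)cc(F)cc2F)C(=O)/C(=C/c2c(F)cc(F)cc2F)C1` is the trifluorinated counterpart of compound 1; the difference between the two cores is not broken down here. For compound 2 this assay reports only a limit, > 10000 nM, consistent with the limit of > 10000 nM in this assay, at which 1 of the 3 values shown sits.

Compound 4 `CCN1C/C(=C\c2c(F)cc(F)cc2F)C(=O)/C(=C/c2c(F)cc(F)cc2F)C1` has not yet been measured in this assay. It differs from compound 2 by methyl in place of hydrogen on a saturated chain carbon bound to an amine nitrogen in a ring, the same change, at the same place, as from compound 1 to compound 3. Because the step of a 1.4-fold higher number from compound 1 to compound 3 (0.14 log units; within the scatter) left the value within the scatter, compound 4 is expected to stay near compound 2, with a step that the limit leaves unreadable from compound 2 to compound 4. Compound 4 is therefore estimated at 15000 nM, with a likely range from 7000 nM to 40000 nM, and most probably reported again only as a limit.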

Compound 4, half-maximal inhibitory concentration: 1100 nM
Beside the measured number, compound 4's estimate is 14-fold (1.13 log units) above it, and the stated range ends above it.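

Methyl in place of hydrogen on a saturated chain carbon bound to an amine nitrogen in a ring does not carry over as one fixed step from one core to the other in this assay: the same change on two cores in this assay, a 1.4-fold higher number (0.14 log units; within the scatter) from compound 1 to compound 3 and an at least 9.0-fold lower number (0.95 log units; beyond the scatter) from compound 2 to compound 4, at least 12-fold (1.09 log units) apart, beyond the scatter of two such steps

On the trifluorinated core of compound 2, the change gives an at least 9.0-fold lower number from compound 2 to compound 4 (0.95 log units; beyond the scatter), which fixes only the smallest size of the step, and the two cores alone neither explain the difference nor set a rule for any other core. In this assay compound 2 gives > 10000 nM, which is a limit of the assay and not a number.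

Still open, from the compounds shown here alone, is whether a longer chain, such as propyl, or a benzyl group on the ring amine nitrogen would follow the methyl-to-ethyl result on either core. The compounds shown also leave open whether the core dependence extends to other aryl groups, such as a chlorophenyl or methoxyphenyl group, in place of the fluorinated rings.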